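Aryl-alkyne para-substituent changes in a nitrochromene series

A few compounds are considered here, and "the series" means these few. Any claim that something is new, unique, unknown or untested is made for them only; others in the source may bear on it.

Measured so far:
compound 1 `O=[N+]([O-])C1=Cc2cccc(I)c2OC1C(F)(F)F`: 4090 nM
compound 2 `O=[N+]([O-])C1=Cc2cc(C#Cc3ccc(F)cc3)ccc2OC1C(F)(F)F`: 8860 nM
compound 3 `O=[N+]([O-])C1=Cc2cc(C#Cc3ccc(CO)cc3)ccc2OC1C(F)(F)F`: 2000 nM

In an assay on 1321N1 cells for antagonist activity at P2Y purinoceptor 6 (Homo sapiens), read by FLIPR and calcium flux (a lower number here means a stronger inhibitor, a higher number a weaker inhibitor), compound 3 gives the lowest number of the three, and its gaps to compound 1 and to compound 2 both lie beyond the scatter. Compound 4 `O=[N+]([O-])C1=Cc2cc(C#Cc3ccc(Cl)cc3)ccc2OC1C(F)(F)F` differs from compound 3 by chloro in place of hydroxymethyl on an aromatic carbon. Going by the values given here, the only measured step that bears on this is a 4.4-fold lower number from compound 2 to compound 3 (0.65 log units; beyond the scatter), where the hydroxymethyl group replaced a halogen on the same carbon. Compound 4 returns that carbon to a halogen, so the expected step is back towards the number of compound 2, namely a 3.0-fold higher number from compound 3 to compound 4 (0.48 log units; beyond the scatter). For compound 4 in this assay the estimate is 6000 nM, with a range from 2500 nM to 15000 nM.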

Compound 4, half-maximal inhibitory concentration: 5350 nM
The estimate for compound 4 lay 1.1-fold (0.05 log units) above the measured number, and the stated range covers the measured number.
By their numbers in this assay, from the lowest: compound 3; then compounds 1, 4 and 2 (each within the scatter of the next, the first and the last beyond it).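

In this assay hydroxymethyl keeps its lead at this aromatic carbon against a second halogen, not just against fluoro (a 2.7-fold higher number from compound 3 to compound 4 (0.43 log units; beyond the scatter)). Chloro and fluoro at this carbon cannot be told apart (a 1.7-fold lower number from compound 2 to compound 4 (0.22 log units; within the scatter)), so the gain seen with compound 3 does not depend on which of these two halogens is the comparator. Nothing available explains the hydroxymethyl result.

From the compounds shown here alone, whether the hydroxyl of hydroxymethyl matters remains open, since a methyl or methoxy group at this carbon would be needed to test it. An amine, a carboxylic acid or a longer chain ending in a hydroxyl could also show whether compound 3 can be improved on.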